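From a cyclopropyl to a methyl on the imide nitrogen

The source may report more compounds than this note shows. Statements on the series, on what has been measured and on what is new or still open speak of the compounds shown alone.

Two compounds share a fused bicyclic core. Compound 1 `CN1C(=O)C2=C(C1=O)N(CC(=O)Nc1ccc(-c3ccccc3)nn1)CCC2` gives 36 mL.min-1.g-1 in an ADME assay on microsomes from liver (Mus musculus) for metabolic stability; on this read-out higher numbers stand for fast clearance and lower numbers for slow clearance. Compound 2 `Cc1ccc(-c2ccc(NC(=O)CN3CCCC4=C3C(=O)N(C3CC3)C4=O)nn2)cn1` gives 15 mL.min-1.g-1 in this assay, the lower of the two numbers, with compound 1 lying higher by a gap beyond the scatter. The two differ in more than one place, so their gap is not tied to a single change. Compound 3 `Cc1ccc(-c2ccc(NC(=O)CN3CCCC4=C3C(=O)N(C)C4=O)nn2)cn1` differs from compound 2 by methyl in place of cyclopropyl on an amide-type nitrogen in a ring. A modest rise in clearance is expected, since compound 1, which also bears the methyl, gives 36 mL.min-1.g-1. Compound 3 is estimated at 22 mL.min-1.g-1, between 11 mL.min-1.g-1 and 44 mL.min-1.g-1, a step of a 1.5-fold higher number from compound 2 to compound 3 (0.17 log units; within the scatter).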

Compound 3, intrinsic clearance in microsomes in the liver assay: 8 mL.min-1.g-1
Estimate against measurement, compound 3: 2.8-fold (0.44 log units) above; the whole stated range lies above it.
By their numbers in the liver assay, from the lowest: compounds 3 and 2 (each within the scatter of the next); then compound 1.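

In the liver assay, methyl in place of cyclopropyl on the amide-type nitrogen in a ring gives a 1.9-fold lower number from compound 2 to compound 3 (0.27 log units; within the scatter), so these two groups are not told apart at this position, while 6-methylpyridin-3-yl in place of phenyl on an aromatic carbon gives a 4.5-fold lower number from compound 1 to compound 3 (0.65 log units; beyond the scatter). In a physicochemical assay for solubility, measured as thermodynamic solubility, at pH 4 (a higher number here means a more soluble compound, a lower number a less soluble compound), compound 2 gives > 41 ug/mL, which is a limit of the assay. In the physicochemical assay, compound 3 gives > 194 ug/mL, which is also a limit of the assay.

The step between these two limits cannot be read. Going by these compounds, whether an amine or a longer chain on this nitrogen would keep the number in the liver assay this low remains open.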